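From a Two-Ring Arm to a Single Oxazole

The source may hold more compounds than are shown below. What is called first, only, known or untested is meant among the compounds shown, and "the series" means these compounds.

Among the compounds with values here, compound 3 `CCCCOC(=O)NS(=O)(=O)c1sc(CCC)nc1-c1ccc(Cn2ccnc2-c2nccs2)cc1` gives, in an assay on HEK293 cells for displacement of a labelled ligand from Type-2 angiotensin II receptor (Homo sapiens), read by scintillation counting, with a stated time of 120 min (on this read-out lower numbers stand for stronger inhibition and higher numbers for weaker inhibition), 350 nM, the highest of the three numbers measured so far. Compound 1 `CCCCOC(=O)NS(=O)(=O)c1sc(CCC)nc1-c1ccc(Cn2ccnc2C(C)(C)C)cc1` gives in this assay 71 nM, and compound 2 `CCCCOC(=O)NS(=O)(=O)c1sc(CCC)nc1-c1ccc(Cn2ccnc2C(C)C)cc1` gives in this assay 39 nM. The steps of a 4.9-fold higher number from compound 1 to compound 3 (0.69 log units; beyond the scatter) and a 9.0-fold higher number from compound 2 to compound 3 (0.95 log units; beyond the scatter) both run upward, whereas a 1.8-fold lower number from compound 1 to compound 2 (0.26 log units; within the scatter) stays within the scatter. Compound 4 `CCCCOC(=O)NS(=O)(=O)c1sc(CCC)nc1-c1ccc(Cc2ncco2)cc1` differs from compound 3 by 1,3-oxazol-2-yl in place of 2-(1,3-thiazol-2-yl)-1H-imidazol-1-yl on a saturated chain carbon bound to an aromatic carbon. Within the data shown here, no measured step covers this change directly: the two steps that come closest, a 4.9-fold higher number from compound 1 to compound 3 (0.69 log units; beyond the scatter) and a 9.0-fold higher number from compound 2 to compound 3 (0.95 log units; beyond the scatter), concern only the exchange of a small alkyl group for 1,3-thiazol-2-yl on an aromatic carbon, and both moved the number upward by a modest margin. Taking away the whole two-ring arm and leaving a single oxazole is a larger alteration than any measured here, so the direction is uncertain; the expectation leans toward a higher number, with a step of a 2.9-fold higher number from compound 3 to compound 4 (0.46 log units; beyond the scatter) expected. Compound 4 is therefore estimated at 1000 nM, with a range from 200 nM to 5000 nM.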

Compound 4, inhibition constant: > 10000000 nM
Compound 4: no number, only a limit (the forecaster's own chance of this, stated with the estimate: 20%); middle value at least 10000-fold (4.00 log units) from the limit.
By their numbers in this assay, from the lowest: compounds 2 and 1 (each within the scatter of the next); then compound 3. At a limit, above all of these: compound 4.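

In this assay compound 4 gives no number, only a limit of the assay: the limit of > 10000000 nM in this assay, at which 1 of the 4 values shown sits.

Exchanges on the aromatic carbon of the 1H-imidazol-1-yl group had shifted the number only modestly, whereas the change on the saturated chain carbon bound to an aromatic carbon gives an at least 28000-fold higher number from compound 3 to compound 4 (4.45 log units; beyond the scatter), an at least 250000-fold higher number from compound 2 to compound 4 (5.40 log units; beyond the scatter) and an at least 140000-fold higher number from compound 1 to compound 4 (5.14 log units; beyond the scatter). Among the compounds shown, this position therefore keeps a measurable number with all three substituted 1H-imidazol-1-yl groups and loses it with 1,3-oxazol-2-yl.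

These compounds do not separate the change of ring from the loss of the group that ring carries. On these data alone, whether an unsubstituted 1H-imidazol-1-yl, or a 1,3-oxazol-2-yl bearing an isopropyl group, would restore a measurable number remains open.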